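Combining Two Silent Substitutions on a Shared Core

The source may hold more compounds than are shown below. What is called first, only, known or untested is meant among the compounds shown, and "the series" means these compounds.

Compound 1 `COc1cc(/C=C2\C(=O)Nc3ccccc32)ccc1OCCCN1CCN(c2ccccn2)CC1` sits in a functional assay on BT-549 cells (Homo sapiens) for cytotoxicity, read by MTT assay, with a stated time of 48 h (on this read-out lower numbers stand for stronger inhibition and higher numbers for weaker inhibition), at the limit > 20000 nM, not a number.
Compound 2 `COc1cc(/C=C2\C(=O)Nc3ccc(Cl)cc32)ccc1OCCCN1CCN(c2ccccn2)CC1` sits at the limit > 20000 nM in this assay.
Compound 3 `COc1cc(/C=C2\C(=O)Nc3ccccc32)ccc1OCCCN1CCN(c2ncccc2C(F)(F)F)CC1` sits at the limit > 20000 nM in this assay.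

Compound 3 therefore stands only at a limit, as do the other two values shown; all three meet at the limit of > 20000 nM in this assay, at which 3 of the 3 values shown sit, so no order among them can be read. The unmeasured compound 4 `COc1cc(/C=C2\C(=O)Nc3ccc(Cl)cc32)ccc1OCCCN1CCN(c2ncccc2C(F)(F)F)CC1` differs from compound 3 by chloro in place of hydrogen on an aromatic carbon. Among the measured compounds shown here, two measured steps bear on this change. The same chloro for hydrogen on the core, taken from compound 1 to compound 2, gave a step that the two limits leave unreadable from compound 1 to compound 2. The trifluoromethyl for hydrogen step from compound 1 to compound 3 gave a step that the two limits leave unreadable from compound 1 to compound 3. Both pieces of compound 4 have thus already appeared separately without bringing any value below the limit, so no readable step in this assay is expected in either direction, and a further limit is the most likely outcome.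

Compound 4 is expected to give about 35000 nM in this assay, with a range from 12000 nM to 120000 nM. The estimated step that the limit leaves unreadable from compound 3 to compound 4 is thus expected to be none beyond the scatter.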

Compound 4, half-maximal inhibitory concentration: 1530 nM
Compound 4: middle estimate off by 23-fold (1.36 log units), on the high side, and the stated range ends above it.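

In this assay, with trifluoromethyl already in place, chloro in place of hydrogen on an aromatic carbon of the shared core gives an at least 13-fold lower number from compound 3 to compound 4 (1.11 log units; beyond the scatter). Read from the other side, with chloro already in place, trifluoromethyl in place of hydrogen gives an at least 13-fold lower number from compound 2 to compound 4 (1.11 log units; beyond the scatter). The steps from compound 1 cannot be read, so the effect of either group alone remains unknown, but this chloro position, which looked silent in the earlier compounds, gives a readable value when trifluoromethyl is also present, and compound 4 is the only compound shown that carries both groups.

As far as these compounds go, whether bromo or fluoro on the same aromatic carbon, or a nitrile in place of trifluoromethyl, would also bring a value under the limit stays open, as does whether a longer chain in the linker would keep the value of compound 4. The true size of both steps also stays open, for each rests on a limit and not on a number: the limit of > 20000 nM in this assay, at which 3 of the 4 values shown sit.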